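The source may hold more compounds than are shown below. What is called first, only, known or untested is meant among the compounds shown, and "the series" means these compounds.

Within the data shown here, compound 2 `CC(Oc1ccccc1S(C)(=O)=O)C1=NCCN1` gives 0.45 in an assay on CHO cells with Alpha-2B adrenergic receptor (Homo sapiens) as the target (a lower number here means a smaller maximal response, a higher number a larger maximal response), the lowest of the two values measured so far; its nearest neighbour is compound 1 `CC(Oc1ccccc1OC1CC1)C1=NCCN1`, which in this assay gives 0.6. Among the measured compounds shown here, the only measured step is a number 0.15 lower from compound 1 to compound 2 (beyond the scatter). Compound 3 `CC(Oc1ccccc1C=O)C1=NCCN1` has not yet been measured; it differs from compound 2 by formyl in place of methylsulfonyl on an aromatic carbon. For the measured compounds named here, no measured step exchanges methylsulfonyl for formyl, so the step from compound 1 to compound 2 bears on it only as the single example of a change of the group on the aromatic carbon, and that step was modest. A step of similar size in either direction, or none beyond the scatter, is therefore plausible for compound 3. The expected step a number 0.050 higher from compound 2 to compound 3 (within the scatter) is small, and compound 3 is estimated to give 0.5 in this assay, within a range from 0.35 to 0.7.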

Compound 3, intrinsic activity: the largest response reached, as a fraction of the reference agonist's: 0.5
Beside the measured number, compound 3's estimate shows no gap at the digits printed; low and high end bracket the measured number.
By their numbers in this assay, from the lowest: compounds 2, 3 and 1 (each within the scatter of the next, the first and the last beyond it).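

In this assay, formyl in place of methylsulfonyl on the aromatic carbon gives a number 0.050 higher from compound 2 to compound 3 (within the scatter), and formyl in place of cyclopropyloxy gives a number 0.10 lower from compound 1 to compound 3 (within the scatter). Compound 3 therefore cannot be separated from either of the other two compounds, although those two stand apart from each other, so at this position a group of 2 heavy atoms with a single hydrogen-bond acceptor falls inside the span the larger groups had set. Nothing available explains these values or the difference between the groups.

From the compounds shown here alone, it remains open whether an amine, a carboxylic acid or a longer alkyl chain on this aromatic carbon would take the maximal response outside that span. It is also open whether a group with a hydrogen-bond donor at this place, such as hydroxyl, would behave like the three groups shown.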